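The source may report more compounds than this note shows. Statements on the series, on what has been measured and on what is new or still open speak of the compounds shown alone.

Working notes on the series. Among the compounds with values here, the three compounds measured so far share one core and differ at the sulfonyl aryl group and at one aromatic carbon of that core. Compound 1 `O=S(=O)(c1cccc2ccccc12)N1CCOc2c(N3CCNCC3)cc(Cl)cc21` carries chloro there and in an assay on HEK293 cells for displacement of a labelled ligand from 5-hydroxytryptamine receptor 6 (Homo sapiens) (on this read-out higher numbers stand for weaker inhibition and lower numbers for stronger inhibition), compound 1 gives 0.794 nM. Compound 2 `Cc1cc(N2CCNCC2)c2c(c1)N(S(=O)(=O)c1ccccc1F)CCO2` carries methyl at that carbon and in this assay compound 2 gives 0.398 nM. Compound 3 `O=S(=O)(c1ccccc1F)N1CCOc2c(N3CCNCC3)cc(F)cc21` carries fluoro and in this assay compound 3 gives 0.631 nM. Compound 3 stands second highest of the three numbers, close to compound 1, and the step of a 1.6-fold higher number from compound 2 to compound 3 (0.20 log units; within the scatter) lies within the scatter, so the methyl-to-fluoro exchange at this carbon left the number where it was.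

Compound 4 `O=S(=O)(c1ccccc1F)N1CCOc2c(N3CCNCC3)cc(Cl)cc21` is the next step: chloro in place of fluoro on an aromatic carbon. Within the data shown here, no measured step exchanges fluoro for chloro with the sulfonyl group held fixed; compound 1 carries chloro but also a different sulfonyl aryl, so its value bears on the question only loosely. Among the measured compounds shown here, the one measured exchange at this carbon, a 1.6-fold higher number from compound 2 to compound 3 (0.20 log units; within the scatter), stayed within the scatter, and compound 1 sits within the scatter of compound 3. No step beyond the scatter is therefore expected in this assay. The expected step is a 1.0-fold lower number from compound 3 to compound 4 (0.00 log units; within the scatter). For compound 4 the estimate in this assay is 0.63 nM, with a range from 0.3 nM to 1.3 nM.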

Compound 4, inhibition constant: 0.398 nM
Compound 4: middle estimate off by 1.6-fold (0.20 log units), on the high side; measured number inside the range.
By their numbers in this assay, from the lowest: compounds 2, 4, 3 and 1 (each within the scatter of the next).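

With the 2-fluorophenyl group held fixed on the sulfonyl sulfur, this aromatic carbon now carries methyl, fluoro and chloro, and in this assay the exchanges read a 1.6-fold lower number from compound 3 to compound 4 (0.20 log units; within the scatter) and no change at the digits printed from compound 2 to compound 4 (within the scatter) and both lie within the scatter, so none of the three groups separates from the others at this position. Within the data shown here, the first exchange at the sulfonyl sulfur with chloro held fixed reads a 2.0-fold lower number from compound 1 to compound 4 (0.30 log units; within the scatter) and also stays within the scatter, so naphthalen-1-yl and 2-fluorophenyl are not told apart on this read-out. No measurement at hand links these results to any property of the groups involved.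

Still open, from the compounds shown here alone, is whether a group of another kind on this aromatic carbon, such as a methoxy group, a nitrile, a trifluoromethyl group or an amine, would give a step beyond the scatter in this assay. Also open is whether a sulfonyl substituent other than the two aryl groups shown, such as a pyridyl ring or a short alkyl chain, or a replacement for the piperazin-1-yl group, would do the same.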